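Swapping fluoro for methyl on a short-lived series

The source may report more compounds than this note shows. Statements on the series, on what has been measured and on what is new or still open speak of the compounds shown alone.

Compound 1 `Fc1cc(Cl)c2[nH]cc(-c3ccc4ccccc4n3)c2c1` gives 0.383 h
Compound 2 `Fc1cc(F)c2[nH]cc(-c3ccc4ccccc4n3)c2c1` gives 0.45 h
Compound 3 `Cc1cccc2c(-c3ccc4c(F)cccc4n3)c[nH]c12` gives 0.217 h

All three numbers come from an ADME assay on microsomes from liver (Homo sapiens) for metabolic stability, using NADPH, with a stated time of 40 min, tested at 2 uM (on this read-out lower numbers stand for a shorter-lived compound and higher numbers for a longer-lived compound), and are read as half-lives. Compound 2 at 0.45 h lies within the usual scatter of compound 1, whereas compound 3 at 0.217 h stands clearly lower.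

The next compound is compound 4 `Cc1cc(F)cc2c(-c3ccc4ccccc4n3)c[nH]c12` with one change from compound 2: methyl in place of fluoro on an aromatic carbon (methyl in place of fluoro on an aromatic carbon, ortho to a fused ring). For the measured compounds named here, the only measured single change on that carbon is a 1.2-fold higher number from compound 1 to compound 2 (0.07 log units; within the scatter) for fluoro in place of chloro. That step was small, but no methyl took part in it. Compound 3 does carry a methyl group and gives 0.217 h but differs in other places too, so it is only a loose guide pointing lower. A modest fall no larger than the scatter is therefore expected in this assay with a 1.4-fold lower number from compound 2 to compound 4 (0.15 log units; within the scatter) as the estimated step. For compound 4 the estimate is 0.32 h with 0.19 h to 0.52 h as its expected range.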

Compound 4, half-life: 1.1 h
Beside the measured number, compound 4's estimate is 3.4-fold (0.54 log units) below it, outside the stated range (above it).
By their numbers in this assay, from the lowest: compounds 3, 1 and 2 (each within the scatter of the next, the first and the last beyond it); then compound 4.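

In this assay, this carbon, ortho to a fused ring, proves sensitive to the group it carries: methyl in place of fluoro gives a 2.4-fold higher number from compound 2 to compound 4 (0.39 log units; beyond the scatter), and methyl in place of chloro gives a 2.9-fold higher number from compound 1 to compound 4 (0.46 log units; beyond the scatter), both clear of the scatter. The earlier swap between the two halogens, a 1.2-fold higher number from compound 1 to compound 2 (0.07 log units; within the scatter), could not show this, so among the three groups shown at this carbon, methyl alone separates from the others. Nothing available here explains why methyl gives the longer half-life.

On these data alone, whether an ethyl group, a longer chain, an amine or a carboxylic acid on this carbon would go further in the same direction remains open. Compound 3 also carries a methyl group and gives 0.217 h, but it differs from compound 4 in more than one place, so how far the methyl effect holds elsewhere in the series is unsettled.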